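Swapping 4-bromophenyl for 2-ethylphenyl in compound 2

The compounds below may be only part of what the source reports. "The series", "measured", "known", "first", "only" and "open" are said of these compounds alone.

Measured in a functional assay on A549 cells (Homo sapiens) for antiproliferative activity, read by MTT assay; a lower number here means a stronger inhibitor, a higher number a weaker inhibitor:
- compound 1 `CC1(C)CCc2cc(C(=O)/C=C/c3ccc(OCc4cn(-c5ccc(Cl)cc5)nn4)cc3)c(O)cc2O1`: 75500 nM
- compound 2 `CC1(C)CCc2c(ccc(C(=O)/C=C/c3ccc(OCc4cn(-c5ccc(Br)cc5)nn4)cc3)c2O)O1`: 129000 nM

For the measured compounds named here, with only two measurements, compound 2 can be placed only against compound 1, and the two numbers lie within the usual scatter of each other. They cannot be ranked. These two compounds also differ in more than one place, so they show no effect of any single change.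

Compound 3 `CCc1ccccc1-n1cc(COc2ccc(/C=C/C(=O)c3ccc4c(c3O)CCC(C)(C)O4)cc2)nn1` keeps the core of compound 2 but has 2-ethylphenyl in place of 4-bromophenyl on an aromatic nitrogen. Going by the values given here, no measured pair shows what this swap does, so no step beyond the scatter is expected in this assay, in either direction. The estimated change is a 1.3-fold lower number from compound 2 to compound 3 (0.11 log units; within the scatter). For compound 3, the estimated value is 100000 nM, with an expected range of 40000 nM to 250000 nM.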

Compound 3, half-maximal inhibitory concentration: 112000 nM
Compound 3: the middle estimate sits 1.1-fold (0.05 log units) below what was measured; the range from low to high includes it.
By their numbers in this assay, from the lowest: compounds 1, 3 and 2 (each within the scatter of the next).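

In this assay, for the compounds shown here, this is the first comparison that changes one place only, and it gives a 1.2-fold lower number from compound 2 to compound 3 (0.06 log units; within the scatter). At this aromatic nitrogen, 2-ethylphenyl can therefore stand in for 4-bromophenyl without a change that can be told apart from the scatter, even though the groups differ in their substituent and where it is attached, so compound 2 and compound 3 cannot be ranked. No other measurement here bears on this result.

The compounds shown leave open whether any group at this position can give a step beyond the scatter. An amine or a carboxylic acid on the phenyl ring, or a longer chain in place of ethyl, would test this.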